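The source may report more compounds than this note shows. Statements on the series, on what has been measured and on what is new or still open speak of the compounds shown alone.

Measured so far:
compound 1, `COc1cc(OC)c2c(=O)cc(/C=C/c3ccncc3)oc2c1`: > 40000 nM
compound 2, `COc1cccc2oc(/C=C/c3ccc(OC(F)(F)F)cc3)cc(=O)c12`: > 40000 nM
compound 3, `COc1cc(OC)c2c(=O)cc(/C=C/c3ccc(C(F)(F)F)cc3)oc2c1`: > 40000 nM

All three compounds share a core and differ in the outer aromatic ring and its substituents. In a functional assay on PC-3 cells (Homo sapiens) for antiproliferative activity, read by MTT assay, with a stated time of 12 h (on this read-out lower numbers stand for stronger inhibition and higher numbers for weaker inhibition), compound 1 gives > 40000 nM, which is a limit of the assay rather than a number. Compound 2 likewise gives > 40000 nM, also a limit. Compound 3 gives > 40000 nM, again a limit and not a measured number. Within the data shown here, compound 3 therefore stands at the limit of > 40000 nM in this assay, at which 3 of the 3 values shown sit, and with every value a limit, no step between measured compounds can be read from these data.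

Compound 4, `COc1cc(OC)c2c(=O)cc(/C=C/c3ccc(Br)cc3)oc2c1`, is the next compound to be tested in this assay. Compared with compound 3 it carries bromo in place of trifluoromethyl on an aromatic carbon. Since the change is small and nothing measured here points in either direction, the expected step that the limit leaves unreadable from compound 3 to compound 4 is none beyond the usual scatter. Compound 4 is therefore expected to give about 50000 nM, between 15000 nM and 200000 nM, most likely reported only as a limit once more.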

Compound 4, half-maximal inhibitory concentration: > 40000 nM
Compound 4 gave a limit, no number (the forecaster's own chance of this, stated with the estimate: 75%); the middle value does not contradict the limit.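

In this assay compound 4 gives > 40000 nM, again a limit and not a number. No step can be read from compound 3 or compound 1 to compound 4: the limit of > 40000 nM in this assay, at which 4 of the 4 values shown sit. The compounds shown leave open which outer aromatic ring or substituent, if any, would give a measured number.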